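Replacing iodo with 1H-imidazol-1-yl: cytotoxicity notes

A few compounds are considered here, and "the series" means these few. Any claim that something is new, unique, unknown or untested is made for them only; others in the source may bear on it.

In an ADME assay on Vero cells (Chlorocebus sabaeus) for cytotoxicity, read by resazurin assay, with a stated time of 72 h (on this read-out higher numbers stand for lower toxicity in this test and lower numbers for higher toxicity in this test), compound 1 (`O=C(/C=C/c1ccc([N+](=O)[O-])o1)c1ccc(I)cc1`) gives > 100000 nM as its entry, which is a limit of the assay and not a number. In this assay compound 2 (`O=C(/C=C/c1cccc([N+](=O)[O-])c1)c1ccc(N2CCCCC2)cc1`) has "not determined" (no result reported) as its entry and offers no comparison. Compound 3 (`O=C(/C=C/c1ccc([N+](=O)[O-])o1)c1ccc(-n2ccnc2)cc1`) carries 1H-imidazol-1-yl in place of iodo on an aromatic carbon of the core of compound 1 (1H-imidazol-1-yl in place of iodo on an aromatic carbon). Among the measured compounds shown here, no measured step sizes this change. The expected at least 1.6-fold lower number from compound 1 to compound 3 (0.22 log units; that floor lies within the scatter) is small, toward lower numbers, and may stay within the scatter. Compound 3 is estimated at 60000 nM with an expected range from 20000 nM to 100000 nM in this series.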

Compound 3, half-maximal cytotoxic concentration: > 100000 nM
Compound 3 was reported as a limit; the forecaster's own chance of this, stated with the estimate: 45%; middle value at least 1.6-fold (0.22 log units) away from the limit.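

No new step can be read between compound 1 and compound 3, because both entries are limits and not numbers: the limit of > 100000 nM in this assay, at which 2 of the 3 values shown sit.

The compounds shown leave open whether 1H-imidazol-1-yl in place of iodo changes the half-maximal cytotoxic concentration at all.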